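The source may report more compounds than this note shows. Statements on the series, on what has been measured and on what is new or still open speak of the compounds shown alone.

Among the compounds with values here, compound 1 `Cc1ccc([C@@H]2CN(C)[C@]3(C(=O)Nc4ccccc43)[C@]23Cc2ccccc2C3=O)cc1` is one of three compounds measured in a functional assay on the whole organism (strain Wister albino) for inhibition, with Rattus norvegicus as the target, read by paw edema, with stated times of 1 h and 4 h, at a dose of 50 mg/kg by the intraperitoneal route (a lower number here means less inhibition, a higher number more inhibition at the dose given (going by the name of the read-out)), where compound 1 gives 17.1%. Compound 2 `Cc1ccc([C@@H]2CN(C)[C@]3(C(=O)N(C)c4ccccc43)[C@]23Cc2ccccc2C3=O)cc1` gives 13.9% and compound 3 `CN1C(=O)[C@@]2(c3ccccc31)N(C)C[C@@H](c1cccs1)[C@@]21Cc2ccccc2C1=O` gives 12.9%; the steps of a number 3.2 percentage points lower from compound 1 to compound 2 (within the scatter) and a number 1 percentage points lower from compound 2 to compound 3 (within the scatter) both fall within the scatter, so compound 1 is not set apart from either companion. Compound 4 `COc1ccc([C@@H]2CN(C)[C@]3(C(=O)Nc4ccccc43)[C@]23Cc2ccccc2C3=O)cc1` differs from compound 1 by methoxy in place of methyl on an aromatic carbon. Within the data shown here, no measured step touches this position, and the two steps that exist, at the amide-type nitrogen and at the saturated ring carbon, stayed within the scatter. A step within the scatter is therefore expected, with no direction, and compound 4 is estimated at 17%, between 8% and 26%, which means an expected step of a number 0.1 percentage points lower from compound 1 to compound 4 (within the scatter).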

Compound 4, a percentage reported as inhibition, in the whole organism at one dose (the size of the read-out at that dose, not a potency): 21.8%
Estimate against measurement, compound 4: 4.8 percentage points below, within the range that was stated.
By their numbers in this assay, from the lowest: compounds 3, 2, 1 and 4 (each within the scatter of the next).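

Within the data shown here, this is the first look at the group on the aromatic ring: in this assay, going from 4-methylphenyl to 4-methoxyphenyl gives a number 4.7 percentage points higher from compound 1 to compound 4 (within the scatter). So at this position, a swap that brings in an oxygen and a hydrogen-bond acceptor produces no step beyond the usual spread of repeat measurements. Nothing available explains the step. Still open, from the compounds shown here alone, is whether a different group at this position, such as an amine, a carboxylic acid or a longer chain, would give a step beyond the scatter.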